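A few compounds are considered here, and "the series" means these few. Any claim that something is new, unique, unknown or untested is made for them only; others in the source may bear on it.

Series notes: aryl cyclopropyl ketones, Vero cell tolerance

Compound 1 `CN1CCN(c2ccc(C(=O)C3CC3c3ccc(Cl)cc3)cc2)CC1` carries a 4-methylpiperazin-1-yl group on the aromatic ring that bears the carbonyl. In an ADME assay on Vero cells (Chlorocebus sabaeus) for cytotoxicity, with a stated time of 72 h (a lower number here means that less compound is tolerated, a higher number that more compound is tolerated), compound 1 gives 82.1 ug/mL. Compound 2 `CCCCCCCNc1ccc(C(=O)C2CC2c2ccc(Cl)cc2)cc1` differs from it in one place only, (heptylamino in place of 4-methylpiperazin-1-yl on an aromatic carbon). In this assay, among the compounds with values here, compound 2 gives 398 ug/mL, and the step of a 4.8-fold higher number from compound 1 to compound 2 (0.69 log units; beyond the scatter) is the one comparison available for this change.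

Compound 3 `COc1ccc(C2CC2C(=O)c2ccc(N3CCN(C)CC3)cc2)cc1OC` keeps the 4-methylpiperazin-1-yl group but has a different core; how its core differs from that of compound 1 is not broken down here. In this assay compound 3 gives 77.8 ug/mL, which sits within the scatter of the value of compound 1, so no order between the two is claimed.

Compound 4 `CCCCCCCNc1ccc(C(=O)C2CC2c2ccc(OC)c(OC)c2)cc1` is not yet measured. Relative to compound 3 it shows (heptylamino in place of 4-methylpiperazin-1-yl on an aromatic carbon), and the place lines for this change and for the change from compound 1 to compound 2 read the same, so it is taken as the same change on a second core. Within the data shown here, with only one prior instance, the expectation for compound 4 rests on the single step of a 4.8-fold higher number from compound 1 to compound 2 (0.69 log units; beyond the scatter), and a second core may not answer alike. For compound 4 a step of a 4.1-fold higher number from compound 3 to compound 4 (0.61 log units; beyond the scatter) is expected in this assay. The value of compound 4 is accordingly estimated at 320 ug/mL, with a range of 130 ug/mL to 700 ug/mL.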

Compound 4, half-maximal cytotoxic concentration: 273 ug/mL
Estimate against measurement, compound 4: 1.2-fold (0.07 log units) above; the range from low to high includes it.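

In this assay, heptylamino in place of 4-methylpiperazin-1-yl on the second core gives a 3.5-fold higher number from compound 3 to compound 4 (0.55 log units; beyond the scatter), so the number moves the same way as it did on the core of compound 1. This supports carrying the change between these two cores as a step of similar size, but it rests on one pair per core and says nothing about any other core in the series, nor about how far the tolerated concentration would move there. On the two cores shown, the steps cannot be told apart in size: the same change on two cores in this assay, a 4.8-fold higher number (0.69 log units; beyond the scatter) from compound 1 to compound 2 and a 3.5-fold higher number (0.55 log units; beyond the scatter) from compound 3 to compound 4, 1.4-fold (0.14 log units) apart, within the scatter of two such steps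

The compounds shown leave open which part of the exchange goes with the higher number, as heptylamino differs from 4-methylpiperazin-1-yl at once in having no ring, in its open chain and in its count of hydrogen-bond donors. From the compounds shown here alone, a shorter alkylamino chain such as butylamino, a longer chain such as decylamino, or a ring amine such as morpholin-4-yl or piperidin-1-yl on the same aromatic carbon would be needed to separate these features, and whether a carboxylic acid at the end of the chain fits the same trend also remains unknown.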